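Trifluoromethyl Hydroxyamides as Weak Sulfonylurea Receptor Binders

The source may report more compounds than this note shows. Statements on the series, on what has been measured and on what is new or still open speak of the compounds shown alone.

Compound 1, `Cn1nnnc1-c1ccc(NC(=O)C(C)(O)C(F)(F)F)cc1`, gives 30900 nM in an assay on a protein complex (Cavia porcellus) with sulfonylurea receptors; K-ATP channels (Homo sapiens) as the target; on this read-out higher numbers stand for weaker inhibition and lower numbers for stronger inhibition.
Compound 2, `CC(O)(C(=O)Nc1ccc(Sc2ccccc2)cc1)C(F)(F)F`, gives > 30000 nM in this assay; this is a limit of the assay and not a number.
Compound 3, `CC(O)(C(=O)Nc1ccc(S(=O)(=O)N2CCNCC2)cc1)C(F)(F)F`, gives > 30000 nM in this assay; this too is a limit of the assay and not a number.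

Compound 2 therefore stands at the limit of this assay, with no number of its own; of the three values shown, two sit at that limit (the limit of > 30000 nM in this assay, at which 2 of the 3 values shown sit). Going by the values given here, the one step that joins it to a measured neighbour, a step that the limit leaves unreadable from compound 1 to compound 2, cannot be read in size for the same reason.

Compound 4, `CC(O)(C(=O)Nc1ccc(-c2nn[nH]n2)cc1)C(F)(F)F`, differs from compound 2 in one place: 2H-tetrazol-5-yl in place of phenylsulfanyl on an aromatic carbon. Only the unreadable step from compound 1 to compound 2 bears on this change, and compound 1, which carries a 1-methyl-1H-tetrazol-5-yl at that position, gives 30900 nM. Among the compounds with values here, no step of readable size therefore supports any expectation of movement beyond the scatter, and the step from compound 2 to compound 4 is expected to be about none, a number no higher from compound 2 to compound 4 (the limit leaves the size open). Compound 4 is accordingly estimated to give about 30000 nM in this assay, within a range of 10000 nM to 100000 nM, with a substantial chance that only a limit is reported.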

Compound 4, half-maximal inhibitory concentration: > 30000 nM
Compound 4: a limit, no number; the forecaster's own chance of this, stated with the estimate: 55%; the middle value lies on the limit itself.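

In this assay compound 4 gives > 30000 nM, which is a limit of the assay and not a number. No size can therefore be read for the steps joining compound 4 to compound 2 or to compound 1: the limit of > 30000 nM in this assay, at which 3 of the 4 values shown sit.

The compounds shown leave open how compound 2, compound 3 and compound 4 rank against one another and against compound 1.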